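The source may report more compounds than this note shows. Statements on the series, on what has been measured and on what is new or still open speak of the compounds shown alone.

Among the measured compounds shown here, compound 2 `CCc1ccccc1-n1nncc1CN1C(=O)C2(C(C#N)=C(N)Oc3c(N)cc4nc5ccccc5nc4c32)c2ccccc21` gives 24600 nM in a functional assay on MCF7 cells (Homo sapiens) for antiproliferative activity, read by MTT assay, with a stated time of 48 h (a higher number here means a weaker inhibitor, a lower number a stronger inhibitor), and is the only compound with a number rather than a limit. Compound 1 `Cc1cccc(-n2nncc2CN2C(=O)C3(C(C#N)=C(N)Oc4c(N)cc5nc6ccccc6nc5c43)c3ccccc32)c1` sits at the assay limit, > 50000 nM (the limit of > 50000 nM in this assay, at which 1 of the 2 values shown sits). For the measured compounds named here, the one measured step, an at least 2.0-fold lower number from compound 1 to compound 2 (0.30 log units; that floor lies within the scatter), is an aryl swap on the same aromatic nitrogen, with a floor that lies inside the scatter. Compound 3 `N#CC1=C(N)Oc2c(N)cc3nc4ccccc4nc3c2C12C(=O)N(Cc1cnnn1-c1ccc(Cl)cc1)c1ccccc12` carries the change (4-chlorophenyl in place of 2-ethylphenyl on an aromatic nitrogen). Going by the values given here, with that single aryl step as the only guide, for compound 3 the expected step is a 1.0-fold higher number from compound 2 to compound 3 (0.01 log units; within the scatter). Compound 3 is therefore estimated at 25000 nM, with a range of 8000 nM to 80000 nM.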

Compound 3, half-maximal inhibitory concentration: > 50000 nM
Compound 3: no number, only a limit (the forecaster's own chance of this, stated with the estimate: 30%); middle value at least 2.0-fold (0.30 log units) from the limit.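

In this assay, the change on the aromatic nitrogen gives an at least 2.0-fold higher number from compound 2 to compound 3 (0.30 log units; that floor lies within the scatter), so 4-chlorophenyl, like 3-methylphenyl, yields no measured number at this position. The step between the two compounds at a limit cannot be read. Compound 3 gives a limit and not a number, and compound 2 remains the only compound with a number: the limit of > 50000 nM in this assay, at which 2 of the 3 values shown sit.

As far as these compounds go, both readable floors lie within the scatter, so whether 2-ethylphenyl truly separates from the other two aryl groups remains open. Also open, from the compounds shown here alone, is how a phenyl ring bearing an amine or a carboxylic acid would read here.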